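The source may report more compounds than this note shows. Statements on the series, on what has been measured and on what is new or still open speak of the compounds shown alone.

Compound 1 `C#CCOc1ccc(/C=C/C(=O)c2cccn2C)cc1OC`: > 50000 nM, a limit of the assay rather than a number.
Compound 2 `C#CCOc1ccc(/C=C/C(=O)c2ccccc2C)cc1OC`: 6950 nM.

Both values come from a functional assay on CCRF-CEM cells (Homo sapiens) for cytotoxicity, with a stated time of 72 h; on this read-out higher numbers stand for weaker inhibition and lower numbers for stronger inhibition. Compound 1 reaches only a limit (the limit of > 50000 nM in this assay, at which 1 of the 2 values shown sits). For the measured compounds named here, compound 2 is therefore the only compound with a measured number. Going by the values given here, the one measured step, an at least 7.1-fold lower number from compound 1 to compound 2 (0.85 log units; beyond the scatter), exchanged the whole ring on the carbonyl carbon. Compound 3 `C#CCOc1ccc(/C=C/C(=O)c2ccc(C)cc2)cc1OC` differs from compound 2 by 4-methylphenyl in place of 2-methylphenyl on a carbonyl carbon. Among the compounds with values here, no measured step moves a methyl around a phenyl, so the step from compound 2 to compound 3 is expected to stay within the scatter, a 1.0-fold higher number from compound 2 to compound 3 (0.00 log units; within the scatter). Compound 3 is estimated at 7000 nM, between 2500 nM and 20000 nM.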

Compound 3, half-maximal inhibitory concentration: > 50000 nM
Compound 3: a limit, no number (the forecaster's own chance of this, stated with the estimate: 10%); middle value at least 7.1-fold (0.85 log units) from the limit.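

Only the methyl moves on the ring, yet the change gives an at least 7.1-fold higher number from compound 2 to compound 3 (0.85 log units; beyond the scatter). At this carbonyl carbon, then, where the methyl sits on the phenyl counts, and not only which ring is attached. Compound 3 gives a limit and not a number, as does compound 1, so the step between those two cannot be read: the limit of > 50000 nM in this assay, at which 2 of the 3 values shown sit.

Open, on these data alone, is how far the true value of compound 3 lies from that limit. Also open, as far as these compounds go, is whether an ethyl or a methoxy group in place of the methyl of 2-methylphenyl would keep a measurable number.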